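The compounds below may be only part of what the source reports. "The series", "measured", "known", "first", "only" and "open" are said of these compounds alone.

Compound 1 `Cc1cc(=O)n(-c2ccccc2OC(F)(F)F)nc1C(=O)Nc1ccc(Oc2ncnc3ccsc23)cc1`: 10100 nM
Compound 2 `Cc1ccc(-n2nc(C(=O)Nc3ccc(Oc4ncnc5ccsc45)cc3)c(C)cc2=O)c(C)c1`: 16400 nM
Compound 3 `Cc1cc(=O)n(-c2ccccc2OC(F)(F)F)nc1C(=O)Nc1ccc(Oc2ncnc3ccsc23)c(F)c1`: 5720 nM

In a functional assay on A549 cells (Homo sapiens) for cytotoxicity, read by MTT assay, with a stated time of 72 h (a higher number here means a weaker inhibitor, a lower number a stronger inhibitor), compound 1 gives 10100 nM, the second highest of the three numbers. Its two neighbours stay close: a 1.6-fold higher number from compound 1 to compound 2 (0.21 log units; within the scatter), and a 1.8-fold lower number from compound 1 to compound 3 (0.25 log units; within the scatter), so all three compounds sit within the scatter of one another.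

Compound 4 `Cc1cc(=O)n(-c2ccccc2OC(F)(F)F)nc1C(=O)Nc1ccc(Oc2ncnc3sccc23)cc1` is built from the same atoms as compound 1, joined differently: a group of 9 heavy atoms (6 carbon, 2 nitrogen, 1 sulfur; one five-membered aromatic ring with 1 hetero atom, one six-membered aromatic ring with 2 hetero atoms) in place of a group of 9 heavy atoms (6 carbon, 2 nitrogen, 1 sulfur; one five-membered aromatic ring with 1 hetero atom, one six-membered aromatic ring with 2 hetero atoms), on an oxygen on an aromatic ring. The change therefore leaves the count of rings, hetero atoms, donors and acceptors unchanged and only rearranges the group that hangs from the oxygen.

Neither measured step touches this part of the molecule; one swaps the aryl group on the aromatic nitrogen, the other adds a fluoro to the central ring, and both stay within the scatter. There is no measured guide for rearranging the bicyclic group, so the expected step in this assay is a 1.0-fold lower number from compound 1 to compound 4 (0.00 log units; within the scatter), that is, none beyond the scatter. Compound 4 is therefore estimated at 10000 nM, with a range from 3500 nM to 28000 nM.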

Compound 4, half-maximal inhibitory concentration: 15500 nM
Estimate against measurement, compound 4: 1.6-fold (0.19 log units) below, within the range that was stated.
By their numbers in this assay, from the lowest: compounds 3, 1, 4 and 2 (each within the scatter of the next, the first and the last beyond it).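

Rearranging the group on the oxygen, while keeping its atoms and its counts of rings, donors and acceptors the same, gives in this assay a 1.5-fold higher number from compound 1 to compound 4 (0.19 log units; within the scatter). This is the only change at this position among the compounds shown, and for this one pair, joining the same atoms differently has no effect that can be read apart from the scatter. No measurement here offers an explanation for how little the number shifts.

A single rearrangement cannot show how much this position would tolerate, so an amine or a carboxylic acid attached to this group could give a very different result in this assay. On these data alone, it also remains open whether the rearranged group would behave the same way alongside the fluoro on the central ring or a 2,4-dimethylphenyl on the aromatic nitrogen.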